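Swapping a Cyanophenyl for a Benzyl on a Piperazine

This account rests on a few compounds, and the source may have more. Where it says the series, first, only, none or still open, it means among the compounds named here.

Measured so far in a functional assay on A-375 cells (Homo sapiens) for antiproliferative activity, read by CCK-8 assay, with a stated time of 72 h, tested at 2 uM; a higher number here means a stronger effect of the compound at the concentration tested, a lower number a weaker effect:
Compound 1, `Nc1ccccc1NC(=O)c1ccc(CSC(=S)N2CCc3cc(Cl)ccc32)cc1`, gives 31.9%.
Compound 2, `CC1CCCCN1C(=S)SCc1ccc(C(=O)Nc2ccccc2N)cc1`, gives 42.5%.
Compound 3, `N#Cc1ccc(N2CCN(C(=S)SCc3ccc(C(=O)Nc4ccccc4N)cc3)CC2)cc1`, gives 41.4%.

Among these three numbers compound 3 stands second highest. Its nearest neighbour is compound 2, and that gap lies within the scatter; its furthest neighbour is compound 1, and even that gap lies within the scatter, so none of the three can be called stronger or weaker than another on the numbers shown.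

Compound 4, `Nc1ccccc1NC(=O)c1ccc(CSC(=S)N2CCN(Cc3ccccc3)CC2)cc1`, has not yet been measured. It differs from compound 3 in one place: benzyl in place of 4-cyanophenyl on an amine nitrogen in a ring. For the measured compounds named here, the only measured step, a number 10.6 percentage points higher from compound 1 to compound 2 (beyond the scatter), changes the group on the thiocarbonyl carbon, not the group on the amine nitrogen in the ring, so it does not bear directly on this change. Going by the values given here, there is no measured step in this set that tests what happens when one group on that ring nitrogen is exchanged for another.

With nothing pointing in either direction, no step beyond the scatter is expected, and compound 4 is estimated at 40%, within 27% to 53%, which corresponds to an expected step of a number 1.4 percentage points lower from compound 3 to compound 4 (within the scatter).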

Compound 4, a percentage reported as inhibition, at one concentration (the size of the read-out at that concentration, not a potency): 10.6%
For compound 4 the middle estimate is 29.4 percentage points above the measured one, and the stated range ends above it.
By their numbers in this assay, from the lowest: compound 4; then compounds 1, 3 and 2 (each within the scatter of the next, the first and the last beyond it).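

For the compounds shown here, the group on this amine nitrogen in a ring clearly matters in this assay: exchanging 4-cyanophenyl for benzyl gives a number 30.8 percentage points lower from compound 3 to compound 4 (beyond the scatter), and this is the first step in the set to test this position. The two groups are alike in some ways, since each brings one six-membered aromatic ring of carbon only, so having such a ring at this position does not by itself keep the number up. The change does two things at once, removing the nitrile and placing a carbon between the aromatic ring and the ring nitrogen, and no measurement shown here explains the drop.

As far as these compounds go, what remains open is which of those two differences carries the step, and a plain phenyl or a 4-cyanobenzyl group on the same nitrogen would help to separate them. From the compounds shown here alone, it is also open whether the low number of compound 4 is specific to benzyl, or whether a longer chain such as 2-phenylethyl, or a small group such as methyl, would give a similar result.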